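Hydroxyphenyl replacement at the aryl position of the shared core

A few compounds are considered here, and "the series" means these few. Any claim that something is new, unique, unknown or untested is made for them only; others in the source may bear on it.

Measured compounds in a functional assay on SGC-7901 cells (Homo sapiens) for antiproliferative activity, read by MTT assay, with a stated time of 72 h; a lower number here means a stronger inhibitor, a higher number a weaker inhibitor:
- compound 1 `COc1cc(-n2cnc3ccc(-c4ccc(C)cc4F)cc32)cc(OC)c1OC`: 5650 nM
- compound 2 `COc1cc(-n2cnc3ccc(-c4cccc(O)c4)cc32)cc(OC)c1OC`: 53 nM
- compound 3 `COc1cc(-n2cnc3ccc(-c4cccc(C)c4C)cc32)cc(OC)c1OC`: 3040 nM

Compound 1 gives the highest number of the three. Its nearest neighbour is compound 3, where a 1.9-fold lower number from compound 1 to compound 3 (0.27 log units; within the scatter) stays within the scatter, so the two cannot be ordered. Compound 2 lies far away: a 110-fold lower number from compound 1 to compound 2 (2.03 log units; beyond the scatter) is a large step beyond the scatter, and a 57-fold higher number from compound 2 to compound 3 (1.76 log units; beyond the scatter) shows the same gap from the other side.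

Compound 4 `COc1cc(-n2cnc3ccc(-c4ccc(O)cc4)cc32)cc(OC)c1OC` is not yet measured. Relative to compound 1 the change is 4-hydroxyphenyl in place of 2-fluoro-4-methylphenyl on an aromatic carbon. Among the compounds with values here, the step that bears on it most directly is the one from compound 1 to compound 2, where a hydroxyphenyl group also replaced 2-fluoro-4-methylphenyl and the number fell by a 110-fold lower number from compound 1 to compound 2 (2.03 log units; beyond the scatter). Within the data shown here, compound 4 carries 4-hydroxyphenyl rather than the 3-hydroxyphenyl of compound 2, so the two are not the same change, and no measured pair shows how much that difference matters. A large downward step in this assay is therefore expected, though with a wider range than for compound 2 itself: the step from compound 1 to compound 4 is estimated as a 38-fold lower number from compound 1 to compound 4 (1.58 log units; beyond the scatter). For compound 4 the expected value is 150 nM, with a range from 30 nM to 800 nM.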

Compound 4, half-maximal inhibitory concentration: > 10000 nM
Compound 4: only a limit was reported; the forecaster's own chance of this, stated with the estimate: 5%; at least 66-fold (1.82 log units) between middle value and limit.
By their numbers in this assay, from the lowest: compound 2; then compounds 3 and 1 (each within the scatter of the next). At a limit, above all of these: compound 4.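

In this assay compound 4 gives > 10000 nM, a limit and not a number: the limit of > 10000 nM in this assay, at which 1 of the 4 values shown sits. A hydroxyphenyl group at this aromatic carbon therefore does not by itself give a low number, since the change to 4-hydroxyphenyl in place of 3-hydroxyphenyl shows an at least 180-fold higher number from compound 2 to compound 4 (2.27 log units; beyond the scatter), and among the four compounds shown only the 3-hydroxyphenyl group of compound 2 stands apart from the rest. The same limit separates 4-hydroxyphenyl from 2,3-dimethylphenyl, with an at least 3.2-fold higher number from compound 3 to compound 4 (0.51 log units; beyond the scatter), whereas the comparison with 2-fluoro-4-methylphenyl gives only an at least 1.7-fold higher number from compound 1 to compound 4 (0.24 log units; that floor lies within the scatter), so that pair cannot be ordered beyond the scatter.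

The compounds shown leave open whether the hydroxyl group itself accounts for the low number of compound 2, a question that a 3-methoxyphenyl or 3-aminophenyl group at this carbon would address, and a 2-hydroxyphenyl group would complete the set of hydroxyphenyl isomers. They also do not show how far the true number of compound 4 lies past its limit, or whether this order of compounds holds in any other cell line.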